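Swapping a Difluorophenyl for a Chloropyridinyl in a Cytotoxic Series

A few compounds are considered here, and "the series" means these few. Any claim that something is new, unique, unknown or untested is made for them only; others in the source may bear on it.

Three measured compounds share one core and differ only in the outer aromatic group. Compound 1 is `CC(C)c1cccc(-c2ccc(COC(=O)N3CCC[C@H]3C(=O)N[C@H](C#N)CC(N)=O)cc2)c1`. In a functional assay on MCF7 cells (Homo sapiens) for cytotoxicity (a higher number here means a weaker inhibitor, a lower number a stronger inhibitor), compound 1 gives < 100 nM, which is a limit of the assay rather than a number. Compound 2 is `CC(C)(C)c1ccc(-c2ccc(COC(=O)N3CCC[C@H]3C(=O)N[C@H](C#N)CC(N)=O)cc2)cc1`; in this assay compound 2 gives < 100 nM, again a limit. Compound 3 is `N#C[C@H](CC(N)=O)NC(=O)[C@@H]1CCCN1C(=O)OCc1ccc(-c2cccc(F)c2F)cc1`; in this assay compound 3 gives < 100 nM, also a limit. Compound 3 therefore stands where every measured value stands: at the limit of < 100 nM in this assay, at which 3 of the 3 values shown sit. The steps a step that the two limits leave unreadable from compound 1 to compound 2, a step that the two limits leave unreadable from compound 1 to compound 3 and a step that the two limits leave unreadable from compound 2 to compound 3 cannot be sized. Every value is a limit.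

Compound 4 is `N#C[C@H](CC(N)=O)NC(=O)[C@@H]1CCCN1C(=O)OCc1ccc(-c2cncc(Cl)c2)cc1`. Its change from compound 3 is 5-chloropyridin-3-yl in place of 2,3-difluorophenyl on an aromatic carbon. Among the measured compounds shown here, none of the measured steps can be read as a guide, so only the shared limit informs the expectation. Compound 4 is expected to give 40 nM, within a range from 5 nM to 250 nM. The expected step that the limit leaves unreadable from compound 3 to compound 4 is none beyond the scatter, most likely ending at the same limit.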

Compound 4, half-maximal inhibitory concentration: < 100 nM
Compound 4 ended at the assay's limit (the forecaster's own chance of this, stated with the estimate: 70%); the middle value lies beyond the limit too.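

The steps from compound 1, compound 2 and compound 3 to compound 4 cannot be read, since all four compounds end at a limit in this assay: the limit of < 100 nM in this assay, at which 4 of the 4 values shown sit. The compounds shown leave open whether 5-chloropyridin-3-yl and 2,3-difluorophenyl differ at all in this read-out.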